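The source may hold more compounds than are shown below. What is called first, only, known or untested is meant among the compounds shown, and "the series" means these compounds.

Compound 1 `Cc1cc(CCC#N)cc(C)c1Oc1cc(Nc2ccc(C#N)cc2)c(N)cc1CO` in an ADME assay on TZM cells (Homo sapiens) for cytotoxicity, read by XTT assay, with a stated time of 4 days (a higher number here means that more compound is tolerated, a lower number that less compound is tolerated), gives only a limit, > 23800 nM.
Compound 2 `Cc1cc(CCC#N)cc(C)c1Oc1cc(Nc2ccc(C#N)cc2)c(N)cc1C(F)(F)F` in this assay gives only a limit, > 7100 nM.
Compound 3 `Cc1cc(/C=C/C#N)cc(C)c1Oc1cc(Nc2ccc(C#N)cc2)c(N)cc1C(F)(F)F` in this assay gives 15000 nM.

Compound 1 and compound 2 differ by hydroxymethyl in place of trifluoromethyl on an aromatic carbon, and the step that the two limits leave unreadable from compound 2 to compound 1 cannot be read because the limit of > 23800 nM in this assay, at which 1 of the 3 values shown sits, and the limit of > 7100 nM in this assay, at which 1 of the 3 values shown sits, bound it from both sides. The cores of compound 2 and compound 3 differ by 2-cyanoethenyl in place of 2-cyanoethyl on an aromatic carbon, and the step that the limit leaves unreadable from compound 2 to compound 3 is likewise unreadable because the limit of > 7100 nM in this assay, at which 1 of the 3 values shown sits, sits at one end. Compound 4 `Cc1cc(/C=C/C#N)cc(C)c1Oc1cc(Nc2ccc(C#N)cc2)c(N)cc1CO` is not yet measured; it differs from compound 3 by hydroxymethyl in place of trifluoromethyl on an aromatic carbon, the same change as from compound 2 to compound 1. Since that earlier step is unreadable, the expectation rests on compound 3 alone: its value 15000 nM is taken as the anchor, and the step is estimated as a 1.3-fold higher number from compound 3 to compound 4 (0.12 log units; within the scatter). Compound 4 is thus expected to give about 20000 nM, between 8000 nM and 60000 nM.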

Compound 4, half-maximal cytotoxic concentration in the TZM assay: 16300 nM
Compound 4: middle estimate off by 1.2-fold (0.09 log units), on the high side; low and high end bracket the measured number.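

In the TZM assay, compound 3 gives 15000 nM and compound 4 gives 16300 nM. In the TZM assay, hydroxymethyl in place of trifluoromethyl on the 2-cyanoethenyl core gives a 1.1-fold higher number from compound 3 to compound 4 (0.04 log units; within the scatter), so on this core the change leaves no readable mark. In the TZM assay, the comparison across the two chains gives only an at least 1.4-fold lower number from compound 1 to compound 4 (0.16 log units; that floor lies within the scatter), a floor set by a limit, and the steps that rest on limits cannot be read, so carrying the change from the 2-cyanoethyl core to the 2-cyanoethenyl core is neither confirmed nor refuted. In a physicochemical assay for solubility, with a stated time of 4 h, at pH 7.4 (a higher number here means a more soluble compound, a lower number a less soluble compound), compound 3 gives 0.24 ug/mL and compound 4 gives 3.23 ug/mL. In the physicochemical assay, the same change gives a 13-fold higher number from compound 3 to compound 4 (1.13 log units; beyond the scatter), but this is shown on one core only.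

The compounds shown leave open whether that solubility step also holds on the 2-cyanoethyl core. They also leave open how an amine or a carboxylic acid would behave in place of hydroxymethyl.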